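The compounds below may be only part of what the source reports. "The series", "measured", "known", "first", "only" and "open" are said of these compounds alone.

Three compounds share one core and differ only in the group carried on a short sulfur-linked chain. Compound 1 `COc1cc(-c2nnc(SCC(=O)c3ccccc3)n2N)cc(OC)c1OC` ends in a phenyl ketone. In a functional assay on HeLa cells (Homo sapiens) for antiproliferative activity, read by MTT assay, with a stated time of 48 h (on this read-out lower numbers stand for stronger inhibition and higher numbers for weaker inhibition), compound 1 gives only a limit, > 100000 nM, and the limit of > 100000 nM in this assay, at which 1 of the 3 values shown sits, marks it as such. Compound 2 `COc1cc(-c2nnc(SCC(=O)c3ccc(C)cc3)n2N)cc(OC)c1OC`, with a methyl on the aromatic carbon of that ring, gives 2940 nM in this assay, a large change of an at least 34-fold lower number from compound 1 to compound 2 (1.53 log units; beyond the scatter). Among the measured compounds shown here, compound 3 `COc1cc(-c2nnc(SCC(=O)Nc3ccccc3)n2N)cc(OC)c1OC`, in which an anilino replaces the phenyl on the carbonyl carbon, gives 8280 nM; the step of an at least 12-fold lower number from compound 1 to compound 3 (1.08 log units; beyond the scatter) is also large, while the step of a 2.8-fold higher number from compound 2 to compound 3 (0.45 log units; beyond the scatter) is modest, so compound 3 stands at the higher of the two numbers measured so far.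

Compound 4 `COc1cc(-c2nnc(SCC(=O)Nc3ccccc3F)n2N)cc(OC)c1OC` differs from compound 3 by fluoro in place of hydrogen on an aromatic carbon. For the measured compounds named here, no measured pair tests a fluoro anywhere. The nearest measured step, an at least 34-fold lower number from compound 1 to compound 2 (1.53 log units; beyond the scatter), adds a different small group to the ring of the ketone series. A downward step, smaller than that one, is expected: a 1.7-fold lower number from compound 3 to compound 4 (0.22 log units; within the scatter). Compound 4 is therefore estimated at 5000 nM, in a range from 1500 nM to 20000 nM.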

Compound 4, half-maximal inhibitory concentration: 38200 nM
Compound 4: the middle estimate sits 7.6-fold (0.88 log units) below what was measured; the measured number lies above the stated range.
By their numbers in this assay, from the lowest: compound 2; then compound 3; then compound 4. At a limit, above all of these: compound 1.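

A single fluoro, ortho to a large group on the anilino ring, gives weaker inhibition, a 4.6-fold higher number from compound 3 to compound 4 (0.66 log units; beyond the scatter), whereas the only earlier ring addition, a methyl in the ketone series, gave stronger inhibition. The (2-fluorophenyl)amino group also falls well behind the 4-methylphenyl group, a 13-fold higher number from compound 2 to compound 4 (1.11 log units; beyond the scatter), yet it still improves on the plain phenyl, an at least 2.6-fold lower number from compound 1 to compound 4 (0.41 log units; beyond the scatter). That last step can only be read as a minimum, since compound 1 has a limit rather than a number: the limit of > 100000 nM in this assay, at which 1 of the 4 values shown sits.

The compounds shown leave open whether the loss follows the fluoro itself or its place on the ring. A (4-fluorophenyl)amino group would test the place, and a (2-chlorophenyl)amino or (2-methylphenyl)amino group would test the identity of the added atom or group.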